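A few compounds are considered here, and "the series" means these few. Any claim that something is new, unique, unknown or untested is made for them only; others in the source may bear on it.

Measured so far:
compound 1, `O=C(Nc1cccc(-n2cc(-c3ccncc3)c(-c3cc(O)cc(Cl)c3)n2)c1)Nc1ccc(Cl)c(C(F)(F)F)c1` — in a functional assay on MCF7 cells (Homo sapiens) for inhibition, read by sulforhodamine B assay, with a stated time of 48 h, tested at 1 uM (on this read-out lower numbers stand for a stronger effect and higher numbers for a weaker effect at the one concentration tested), compound 1 gives 91%
compound 2, `O=C(Nc1cccc(-n2cc(-c3ccncc3)c(-c3cc(O)cc(Cl)c3)n2)c1)Nc1ccc(Cl)c(Cl)c1` — in this assay compound 2 gives 91%

On these numbers compound 1 stands level with compound 2: the step of no change at the digits printed from compound 1 to compound 2 (within the scatter) is no change within the scatter, and both read-outs lie at the weak end of the scale. The new compound, compound 3 with structure `COc1cc(Cl)cc(-c2nn(-c3cccc(NC(=O)Nc4ccc(Cl)c(C(F)(F)F)c4)c3)cc2-c2ccncc2)c1`, differs from compound 1 by one small change: methyl in place of hydrogen on an oxygen on an aromatic ring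

For the measured compounds named here, no measured step touches this place in the molecule. Going by the values given here, the only step in hand, no change at the digits printed from compound 1 to compound 2 (within the scatter), changes a group on a different ring, so it shows only that the series tolerated one swap without a shift in the read-out. With nothing that speaks for a move in either direction, the step from compound 1 to compound 3 is expected to be a number 1 percentage points lower from compound 1 to compound 3 (within the scatter), that is, no change beyond the scatter. Compound 3 is therefore estimated at 90%, with a range from 75% to 100%.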

Compound 3, a percentage reported as activity, at one concentration (the size of the read-out at that concentration, not a potency): 50%
For compound 3 the middle estimate is 40 percentage points above the measured one; measured number below the stated range.
By their numbers in this assay, from the lowest: compound 3; then compounds 1 and 2 (each within the scatter of the next).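

The oxygen on the 3-chloro-5-hydroxyphenyl ring turns out to be a sensitive place: in this assay, hydroxy to methoxy gives a number 41 percentage points lower from compound 1 to compound 3 (beyond the scatter) and so shifts the read-out toward a stronger effect. For the compounds shown here, the earlier pair showed only that a swap on a different ring could leave the read-out flat, while this step shows that adding a single methyl on this oxygen is enough to produce a large change. No measurement at hand explains why this small change has such an effect.

The compounds shown leave open whether the shift is specific to methyl or would also appear with a longer chain such as ethyl on the same oxygen, or with an amine in place of the hydroxy. On these data alone, it is also open whether the same step would hold when it is made on compound 2 rather than on compound 1.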